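Three Measured Analogues and One Unmeasured Relative

This account rests on a few compounds, and the source may have more. Where it says the series, first, only, none or still open, it means among the compounds named here.

Of the compounds shown here, three built on one shared core have been measured in an in vitro functional assay on HEK285-7 cells for antagonist activity at prostaglandin D2 receptor 2 (Homo sapiens), read by BRET and beta-arrestin recruitment; a lower number here means a smaller maximal response, a higher number a larger maximal response. Compound 1 `COc1cc(-c2nc(C(c3ccc(F)cc3)c3ccc(F)cc3)sc2CC(=O)O)ccn1` gives 60%. Compound 2 `NS(=O)(=O)c1ccc(-c2nc(C(c3ccc(F)cc3)c3ccc(F)cc3)sc2CC(=O)O)cc1` gives 80%, and compound 3 `O=C(O)Cc1sc(C(c2ccc(F)cc2)c2ccc(F)cc2)nc1-c1ccnc(Cl)c1` gives 80%. Compound 3 thus sits level with compound 2 at the digits shown, and together they are the highest of the three numbers; the step of a number 20 percentage points higher from compound 1 to compound 3 (beyond the scatter) lies beyond the scatter, while the step of no change at the digits printed from compound 2 to compound 3 (within the scatter) stays within it.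

Compound 4 `Nc1cc(-c2nc(C(c3ccc(F)cc3)c3ccc(F)cc3)sc2CC(=O)O)cc(F)n1` has not yet been measured. It differs from compound 3 in one place: 2-amino-6-fluoropyridin-4-yl in place of 2-chloropyridin-4-yl on an aromatic carbon. Within the data shown here, two measured steps bear on this change. Exchanging methoxy for chloro gave the modest step of a number 20 percentage points higher from compound 1 to compound 3 (beyond the scatter), and replacing the whole 4-sulfamoylphenyl by 2-chloropyridin-4-yl gave no change at the digits printed from compound 2 to compound 3 (within the scatter), no change. Because the step of no change at the digits printed from compound 2 to compound 3 (within the scatter) showed no movement when one ring-bearing group replaced another, a step of at most modest size is expected here, a number 5 percentage points lower from compound 3 to compound 4 (within the scatter). Compound 4 is therefore estimated at 75%, within a range from 55% to 90%.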

Compound 4, largest response reached (reported as efficacy), in percent of the reference or control that the assay uses: 30%
For compound 4 the middle estimate is 45 percentage points above the measured one; the measured number lies below the stated range.
By their numbers in this assay, from the lowest: compound 4; then compound 1; then compounds 2 and 3 (each within the scatter of the next).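

Among these compounds, this result shows that the aromatic carbon next to the ring nitrogen is not as forgiving as the earlier compounds suggested: in this assay, keeping the pyridine ring while changing its substituents gives a number 50 percentage points lower from compound 3 to compound 4 (beyond the scatter), a large move. The other comparisons point the same way, with a number 50 percentage points lower from compound 2 to compound 4 (beyond the scatter) and a number 30 percentage points lower from compound 1 to compound 4 (beyond the scatter), so compound 4 gives a smaller maximal response than each of the other three compounds, beyond the scatter. Nothing available explains why this change lowers the number.

The compounds shown leave open whether the amino group, the fluoro group or the two together account for this lower number. A 2-aminopyridin-4-yl or a 2-fluoropyridin-4-yl group at the same place would separate their contributions.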